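Clearance notes on sulfonyl replacements in the shared core

This account rests on a few compounds, and the source may have more. Where it says the series, first, only, none or still open, it means among the compounds named here.

Measured so far in an ADME assay on microsomes from liver (Homo sapiens) for pharmacokinetics, read by LC-MS, with a stated time of 60 min, tested at 1 uM; on this read-out lower numbers stand for slow clearance and higher numbers for fast clearance:
- compound 1 `O=C(NCc1ccc(S(=O)(=O)c2cncc(C(F)(F)F)c2)cc1)N1Cc2ccncc2C1`: 13 mL/min/kg
- compound 2 `CC(C)n1cc(S(=O)(=O)c2ccc(CNC(=O)N3Cc4ccncc4C3)cc2)cn1`: 4 mL/min/kg
- compound 3 `O=C(NCc1ccc(S(=O)(=O)C2CCCOC2)cc1)N1Cc2ccncc2C1`: 7 mL/min/kg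

Compound 1 gives the highest of the three numbers in this assay . Its step to compound 2 is a 3.3-fold lower number from compound 1 to compound 2 (0.51 log units; beyond the scatter), beyond the scatter, while its step to compound 3 is a 1.9-fold lower number from compound 1 to compound 3 (0.27 log units; within the scatter), within the scatter. Between compound 2 and compound 3 the step is a 1.8-fold higher number from compound 2 to compound 3 (0.24 log units; within the scatter), also within the scatter.

Compound 4 `CCC(=O)N1CCC(S(=O)(=O)c2ccc(CNC(=O)N3Cc4ccncc4C3)cc2)CC1` is not yet measured. It differs from compound 1 as follows: 1-propanoylpiperidin-4-yl in place of 5-(trifluoromethyl)pyridin-3-yl on a sulfonyl sulfur. Both steps away from compound 1 bear on this change, since each swaps the same group on the sulfonyl sulfur for a ring bearing one hetero atom, and the change to compound 3, a six-membered non-aromatic ring, is the closer parallel. Both steps point toward a lower number, one beyond the scatter and one within it. For compound 4 the expected step is therefore a 1.9-fold lower number from compound 1 to compound 4 (0.27 log units; within the scatter), toward slower clearance. The expected value for compound 4 in this assay is 7 mL/min/kg, with a range from 3.5 mL/min/kg to 14 mL/min/kg.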

Compound 4, clearance: 11 mL/min/kg
Compound 4: the middle estimate sits 1.6-fold (0.20 log units) below what was measured, within the range that was stated.
By their numbers in this assay, from the lowest: compounds 2, 3, 4 and 1 (each within the scatter of the next, the first and the last beyond it).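

In this assay, 1-propanoylpiperidin-4-yl on the sulfonyl sulfur does not separate from 5-(trifluoromethyl)pyridin-3-yl, with a 1.2-fold lower number from compound 1 to compound 4 (0.07 log units; within the scatter), or from oxan-3-yl, with a 1.6-fold higher number from compound 3 to compound 4 (0.20 log units; within the scatter). Among the replacements shown, only 1-isopropyl-1H-pyrazol-4-yl stands apart from the new group, with a 2.8-fold higher number from compound 2 to compound 4 (0.44 log units; beyond the scatter), so a six-membered non-aromatic ring on this sulfur does not set compound 4 apart from compound 1 or compound 3. Nothing available bears on why these groups give these numbers.

The compounds shown leave open how a piperidin-4-yl carrying a free amine, or a carboxylic acid on a longer chain, in place of the propanoyl group would read in this assay. Also open, on these data alone, is whether a pyrazol-4-yl with a methyl in place of the isopropyl would stay with compound 2.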